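From 4-Methylpiperazin-1-yl to 4-Methylpiperidin-1-yl

The source may hold more compounds than are shown below. What is called first, only, known or untested is meant among the compounds shown, and "the series" means these compounds.

Compound 1 `CN1CCN(c2nc(Cl)nc3c2ncn3Cc2ccc(C(=O)Nc3ccccc3N)cc2)CC1` was tested in a functional assay on HepG2 cells (Homo sapiens) for antiproliferative activity, read by CCK-8 assay, with a stated time of 72 h (on this read-out lower numbers stand for stronger inhibition and higher numbers for weaker inhibition), where compound 1 gives 2010 nM. Compound 2 `Nc1ccccc1NC(=O)c1ccc(COCNc2nc(Nc3ccccc3)c3ncn(C4CCCC4)c3n2)cc1`, a more distantly related structure, gives 6020 nM in this assay; the two numbers lie apart by more than the usual scatter, and compound 1 stands as the lower of the two. Compound 3 `CC1CCN(c2nc(Cl)nc3c2ncn3Cc2ccc(C(=O)Nc3ccccc3N)cc2)CC1` has not yet been measured. It differs from compound 1 in a single place: 4-methylpiperidin-1-yl in place of 4-methylpiperazin-1-yl on an aromatic carbon. The ring size and the methyl group are kept; what changes is the ring itself, which in compound 3 carries fewer hetero atoms and fewer hydrogen-bond acceptors. For the measured compounds named here, no measured pair shows what this exchange does on the shared core, so any expectation rests on compound 1 alone. In this assay the expected step, a 1.3-fold higher number from compound 1 to compound 3 (0.11 log units; within the scatter), is small, leaning toward a somewhat higher number but likely within the scatter. Compound 3 is therefore estimated at 2600 nM in this assay, with a range from 1000 nM to 7000 nM.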

Compound 3, half-maximal inhibitory concentration: 5180 nM
Estimate against measurement, compound 3: 2.0-fold (0.30 log units) below; low and high end bracket the measured number.
By their numbers in this assay, from the lowest: compound 1; then compounds 3 and 2 (each within the scatter of the next).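

In this assay, for the compounds shown here, the exchange of 4-methylpiperazin-1-yl for 4-methylpiperidin-1-yl on this aromatic carbon gives a 2.6-fold higher number from compound 1 to compound 3 (0.41 log units; beyond the scatter) and so provides the first direct reading of this position on the shared core. The two groups match in ring size, in heavy-atom total and in the methyl group, and differ in that a carbon stands in the ring where 4-methylpiperazin-1-yl has its second nitrogen, so this single exchange is enough to move the number beyond the usual scatter, though only modestly. No supporting measurement is available that would explain the shift.

On these data alone, what remains open is how other groups at this place would compare with the 4-methylpiperazin-1-yl of compound 1, for example morpholin-4-yl, which keeps a second ring hetero atom as an oxygen, or piperazin-1-yl without the methyl group. As far as these compounds go, this reading also rests on a single pair in one cell assay, so whether the same exchange has a similar effect with another group in place of the chloro group remains unknown.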